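The source may hold more compounds than are shown below. What is called first, only, known or untested is meant among the compounds shown, and "the series" means these compounds.

Compound 1, with structure `CC(C)(C)[C@@H](N)C(=O)N1CCN(CCCOc2ccc(C(=O)C3CC3)cc2)CC1`, is tested in an assay for binding affinity to histamine H2 receptor (Homo sapiens) (a lower number here means a stronger inhibitor, a higher number a weaker inhibitor), and gives 19100 nM. That is the highest of the three numbers available. Compound 2, structure `CCCCCC(=O)c1ccc(OCCCN2CCN(C(=O)[C@@H](C)NC(=O)OC(C)(C)C)CC2)cc1`, gives 10700 nM in this assay, a difference from compound 1 within the scatter. Compound 3, structure `CCCCCC(=O)c1ccc(OCCCN2CCN(C(=O)[C@H](CC(C)C)NC(=O)OC(C)(C)C)CC2)cc1`, gives 3470 nM in this assay, a difference from compound 1 beyond the scatter.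

Compound 4, structure `NCCC(=O)N1CCN(CCCOc2ccc(C(=O)C3CC3)cc2)CC1`, is not yet measured. It differs from compound 1 in one place: 2-aminoethyl in place of 1-amino-2,2-dimethylpropyl on a carbonyl carbon. Among the measured compounds, the larger side chain of compound 3 sits with the lower number, so the smaller side chain of compound 4 is expected to give, if anything, a slightly higher number, as step a 1.3-fold higher number from compound 1 to compound 4 (0.12 log units; within the scatter). Compound 4 is thus estimated at 25000 nM, in the range 8000 nM to 80000 nM.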

Compound 4, inhibition constant: 100000 nM
Beside the measured number, compound 4's estimate is 4.0-fold (0.60 log units) below it, outside the stated range (above it).
By their numbers in this assay, from the lowest: compound 3; then compounds 2 and 1 (each within the scatter of the next); then compound 4.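

Within the data shown here, on this carbonyl carbon, the group matters: 2-aminoethyl in place of 1-amino-2,2-dimethylpropyl gives a 5.2-fold higher number from compound 1 to compound 4 (0.72 log units; beyond the scatter) in this assay, a single-place comparison that the earlier compounds did not offer. The smaller group also lacks the defined stereocentre, so size, branching and stereochemistry change together and this one step cannot separate them. No available evidence explains the step.

Still open, going by these compounds, is how a longer unbranched chain ending in an amine would compare on this carbonyl carbon. A carboxylic acid in place of the amine is equally untested among the compounds shown.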